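The source may hold more compounds than are shown below. What is called first, only, known or untested is meant among the compounds shown, and "the series" means these compounds.

Working notes on the series. Two compounds share the core shown for compound 1 `CCc1oc2c(C)c(OC)ccc2c(=O)c1Br` and compound 2 `CCOc1ccc2c(=O)cc(CC)oc2c1CBr`, and both have been tested in a functional assay on A549 cells (Homo sapiens) for antiproliferative activity, read by sulforhodamine B assay, with a stated time of 72 h; on this read-out higher numbers stand for weaker inhibition of growth and lower numbers for stronger inhibition of growth. In this assay compound 1 gives > 33600 nM, which is a limit of the assay and not a number. Compound 2 gives > 32100 nM in this assay, again a limit rather than a number. Going by the values given here, compound 2 therefore stands at the limit of > 32100 nM in this assay, at which 1 of the 2 values shown sits, and the only other value available, that of compound 1, sits at the limit of > 33600 nM in this assay, at which 1 of the 2 values shown sits, so no graded comparison between the two is possible.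

The next compound, compound 3 `CCc1cc(=O)c2ccc(OCC(C)C)c(CBr)c2o1`, differs from compound 2 by isopropyl in place of methyl on a saturated chain carbon bound to an oxygen on an aromatic ring. Among the compounds with values here, with both measured values resting at limits, no step between measured compounds exists from which to gauge this change. Given that compound 2 stands at > 32100 nM, the expected step from compound 2 to compound 3 in this assay is a step that the limit leaves unreadable from compound 2 to compound 3, that is none beyond the usual scatter. Compound 3 is accordingly expected to give about 40000 nM in this assay, with a range from 10000 nM to 100000 nM, most likely reported again only as a limit.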

Compound 3, concentration for 50% growth inhibition: > 29400 nM
Compound 3 ended at the assay's limit (the forecaster's own chance of this, stated with the estimate: 70%); the middle value is on the limit's open side.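

In this assay compound 3 gives > 29400 nM, again a limit of the assay and not a number. Going by these compounds alone, compound 2 also rests at a limit, so no step from compound 2 to compound 3 can be read. The compounds shown leave open whether isopropyl in place of methyl at this place changes growth inhibition at all.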